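The compounds below may be only part of what the source reports. "The series", "measured", "known", "first", "only" and "open" are said of these compounds alone.

Compound 1 `CCCCCCCCCCc1ccc(-c2noc(CCCCN)n2)cc1` gives 55% in an assay on HeLa cells for inhibition of sphingosine-1-phosphate transporter SPNS2 (Mus musculus), read by LC-MS, tested at 2 uM; a higher number here means more inhibition at the concentration tested (going by the name of the read-out), a lower number less inhibition. Compound 2 `CCCCCCCCCCc1ccc(-c2noc(CCCNC)n2)cc1` gives 45% in this assay, and compound 3 `CCCCCCCCCCc1ccc(-c2noc(CC3CCNC3)n2)cc1` gives 44%. Compound 3 thus stands lowest of the three numbers: its nearest neighbour is compound 2, with a difference of a number 1 percentage points lower from compound 2 to compound 3 (within the scatter), while the larger gap is a number 11 percentage points lower from compound 1 to compound 3 (beyond the scatter).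

Compound 4 `CCCCCCCCCCc1ccc(-c2noc(CCCN3CCCCC3)n2)cc1` has not yet been measured in this assay. It differs from compound 3 in one place: 2-(piperidin-1-yl)ethyl in place of pyrrolidin-3-yl on a saturated chain carbon bound to an aromatic carbon. Among the measured compounds shown here, no measured step exchanges these two groups directly. The steps that bear most closely on it are those that rework the far end of the chain on the shared core: a number 10 percentage points lower from compound 1 to compound 2 (within the scatter) and a number 1 percentage points lower from compound 2 to compound 3 (within the scatter), both within the scatter, and a number 11 percentage points lower from compound 1 to compound 3 (beyond the scatter), a modest step. Taken together they suggest that changes at this end of the chain move the read-out only a little, so for compound 4 a step of a number 6 percentage points lower from compound 3 to compound 4 (within the scatter) is expected, at most slightly beyond the scatter. Compound 4 is therefore estimated to give about 38% in this assay, within a range of 20% to 55%.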

Compound 4, a percentage reported as inhibition, at one concentration (the size of the read-out at that concentration, not a potency): 0%
Beside the measured number, compound 4's estimate is 38 percentage points above it; the whole stated range lies above it.
By their numbers in this assay, from the lowest: compound 4; then compounds 3, 2 and 1 (each within the scatter of the next, the first and the last beyond it).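

In this assay the far end of the chain turns out not to accept every amine, for the steps among compound 1, compound 2 and compound 3 were modest at most, whereas piperidin-1-yl brings a number 55 percentage points lower from compound 1 to compound 4 (beyond the scatter) and a number 45 percentage points lower from compound 2 to compound 4 (beyond the scatter) as large steps. Set against the ring of compound 3, 2-(piperidin-1-yl)ethyl in place of pyrrolidin-3-yl brings a number 44 percentage points lower from compound 3 to compound 4 (beyond the scatter) and also removes the hydrogen-bond donor counted on the leaving group while adding heavy atoms. Which of these differences accounts for the loss cannot be told from the data, and no supporting measurement is available.

Going by these compounds, it stays open whether a smaller tertiary amine on the same chain, such as dimethylamino or pyrrolidin-1-yl, would keep the read-out. The same question applies to a piperidin-4-yl ring, which would show whether the six-membered ring itself or the substituted nitrogen matters.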